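This account rests on a few compounds, and the source may have more. Where it says the series, first, only, none or still open, it means among the compounds named here.

Compound 2 `CC1=CC[C@H](C(C)(C)NC(=S)N/N=C/c2ccc(F)cc2)CC1` carries a 4-fluorophenyl group on the carbon that is double-bonded to nitrogen. In a functional assay on UACC-62 cells (Homo sapiens) for inhibition, read by sulforhodamine B assay, with a stated time of 48 h (a lower number here means a stronger inhibitor of growth, a higher number a weaker inhibitor of growth), compound 2 gives only a limit, > 100000 nM, not a definite number. That limit is the limit of > 100000 nM in this assay, at which 1 of the 2 values shown sits. Compound 1 `CC1=CC[C@H](C(C)(C)NC(=S)N/N=C/c2ccccc2O)CC1`, which bears a 2-hydroxyphenyl group at that same carbon, gives 10800 nM in this assay. For the measured compounds named here, the step of an at least 9.2-fold higher number from compound 1 to compound 2 (0.96 log units; beyond the scatter) is the only measured comparison available, and it shows a clear weakening of growth inhibition when the ring substituent changes. Compound 3 `CC1=CC[C@H](C(C)(C)NC(=S)N/N=C/c2ccccc2Cl)CC1` brings the next change: 2-chlorophenyl in place of 4-fluorophenyl on a carbon with a double bond to nitrogen. Going by the values given here, no measured step swaps one halogen-bearing ring for another, so the direction of this change is uncertain, and a wide range is appropriate. For compound 3 a value around 50000 nM is expected, with a range from 8000 nM to 200000 nM. This estimate implies an expected step of an at least 2.0-fold lower number from compound 2 to compound 3 (0.30 log units; that floor lies within the scatter).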

Compound 3, concentration for total growth inhibition: 98000 nM
The estimate for compound 3 lay 2.0-fold (0.29 log units) below the measured number; low and high end bracket the measured number.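

Chloro in place of hydroxy on an aromatic carbon gives, in this assay, a 9.1-fold higher number from compound 1 to compound 3 (0.96 log units; beyond the scatter). This single change shows that the weakening seen with the 4-fluorophenyl group of compound 2 also appears when only the hydroxy group of compound 1 is replaced, so growth inhibition here depends on what that aromatic carbon carries. Between the two halogen-bearing rings, the change gives an at least 1.0-fold lower number from compound 2 to compound 3 (0.00 log units; that floor lies within the scatter), and this step sets no order between them because compound 2 has only a limit: the limit of > 100000 nM in this assay, at which 1 of the 3 values shown sits.

The compounds shown leave open whether an amine or a methoxy group on that aromatic carbon would keep the number close to that of compound 1. They also leave open how a plain phenyl ring or a 4-hydroxyphenyl ring would behave at the carbon with a double bond to nitrogen.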